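A few compounds are considered here, and "the series" means these few. Any claim that something is new, unique, unknown or untested is made for them only; others in the source may bear on it.

Measured in a functional assay on the whole organism (strain Sprague-Dawley) for inhibition, with Rattus norvegicus as the target, with a stated time of 10 min; a higher number here means that more compound is needed for the effect, a lower number that less compound is needed:
compound 1 `O=C(O)c1cnc(-c2ccccc2O)[nH]c1=O`: > 5 mg/kg (a limit)
compound 2 `CCC(C)Oc1ccccc1-c1ncc(C(=O)O)c(=O)[nH]1`: 0.5 mg/kg
compound 3 `CCCCCOc1ccccc1-c1ncc(C(=O)O)c(=O)[nH]1`: 3 mg/kg

Only compound 2 and compound 3 have actual numbers, and compound 3, at 3 mg/kg, has the higher of them. For compound 1 the assay reports only a limit, > 5 mg/kg.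

Compound 4 `O=C(O)c1cnc(-c2ccccc2OCC2CC2)[nH]c1=O` is still to be measured. It differs from compound 3 by one change: cyclopropyl in place of butyl on a saturated chain carbon bound to an oxygen on an aromatic ring. In other words, pentyl gives way to cyclopropylmethyl.

The closest evidence is the change at this same oxygen, a 6.0-fold higher number from compound 2 to compound 3 (0.78 log units; beyond the scatter). Capping the free hydroxyl of compound 1 also helped, with an at least 10-fold lower number from compound 1 to compound 2 (1.00 log units; beyond the scatter), while an at least 1.6-fold lower number from compound 1 to compound 3 (0.22 log units; that floor lies within the scatter) gives only a floor. Of the two measured groups, the straight pentyl chain gave the weaker result and sec-butyl the better one. Cyclopropylmethyl is not a straight chain either, so compound 4 is expected to fall between compound 2 and compound 3, though three compounds are thin support for this. The step expected is a 2.5-fold lower number from compound 3 to compound 4 (0.40 log units; beyond the scatter). For compound 4 the estimated value is 1.2 mg/kg, with an expected range from 0.4 mg/kg to 4 mg/kg.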

Compound 4, dose for 50% inhibition: 0.1 mg/kg
Estimate against measurement, compound 4: 12-fold (1.08 log units) above, and the stated range ends above it.
By their numbers in this assay, from the lowest: compound 4; then compound 2; then compound 3. At a limit, above all of these: compound 1.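

At this oxygen the size of the effect turns out to depend strongly on the group's shape: in this assay, cyclopropyl in place of butyl on the saturated chain carbon gives a 30-fold lower number from compound 3 to compound 4 (1.48 log units; beyond the scatter). Cyclopropylmethyl also surpasses the better of the two earlier groups, sec-butyl, with a 5.0-fold lower number from compound 2 to compound 4 (0.70 log units; beyond the scatter), so the gain of sec-butyl over pentyl did not mark the best group at this position. Against the free hydroxyl the step, an at least 50-fold lower number from compound 1 to compound 4 (1.69 log units; beyond the scatter), is only a floor, for compound 1 has only a limit: the limit of > 5 mg/kg in this assay, at which 1 of the 4 values shown sits.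

From the compounds shown here alone, how a cyclobutylmethyl or an isobutyl group on this oxygen would compare stays open, and with it whether the three-membered ring itself carries the gain. Also open, going by these compounds, is how an amide in place of the carboxylic acid would fare alongside cyclopropylmethyl.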